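The source may report more compounds than this note shows. Statements on the series, on what has been measured and on what is new or still open speak of the compounds shown alone.

Measured in a functional assay on MCF7 cells (Homo sapiens) for cytotoxicity, read by MTT assay, with a stated time of 72 h; on this read-out lower numbers stand for stronger inhibition and higher numbers for weaker inhibition:
- compound 1 `NCCCNc1c(C(=O)NCc2ccc(F)cc2)nc(Br)c2cccnc12`: 6000 nM
- compound 2 `O=C(NCc1ccc(F)cc1)c1nc(Br)c2cccnc2c1NCc1ccc(F)cc1`: "not determined" (no result reported)
- compound 3 `O=C(NCCCNc1c(C(=O)NCc2ccc(F)cc2)nc(Br)c2cccnc12)c1ccccc1`: 2000 nM

Of the two numbers available, compound 3 holds the lower, at 2000 nM. Compound 4 `NCCNc1c(C(=O)NCc2ccc(F)cc2)nc(Br)c2cccnc12` departs from it as follows: amino in place of benzamidomethyl on a saturated chain carbon, two bonds along the chain from a nitrogen on an aromatic ring. Among the compounds with values here, only one measured step bears on this, the modest 3.0-fold lower number from compound 1 to compound 3 (0.48 log units; beyond the scatter), where benzoyl replaced hydrogen on an amine nitrogen. Compound 4 lacks that benzoyl, so a modest step of similar size toward a higher number is expected in this assay, though this rests on a single step. The expected change is a 3.0-fold higher number from compound 3 to compound 4 (0.48 log units; beyond the scatter). The estimate for compound 4 is 6000 nM, within a range of 2200 nM to 16000 nM.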

Compound 4, half-maximal inhibitory concentration: 6000 nM
Compound 4: middle estimate and measured number agree at the digits printed; measured number inside the range.
By their numbers in this assay, from the lowest: compound 3; then compounds 1 and 4 (each within the scatter of the next).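

In this assay, amino in place of benzamidomethyl gives a 3.0-fold higher number from compound 3 to compound 4 (0.48 log units; beyond the scatter), so the lower number of compound 3 does not carry over to a compound without the benzoyl. Amino in place of aminomethyl at the same place gives no change at the digits printed from compound 1 to compound 4 (within the scatter), so with a free amine at the chain end, this change does not separate the two compounds. No measurement here explains either step. Open, from the compounds shown here alone, is whether an acetyl group in place of the benzoyl would give a similar number, and whether a longer chain ending in a free amine would stay within the scatter of compound 1.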